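From sec-butyl to allyl on the amine nitrogen

The source may report more compounds than this note shows. Statements on the series, on what has been measured and on what is new or still open speak of the compounds shown alone.

Compound 1, `CCCNC(=C\C(=O)/C=C/c1ccc(O)c(OC)c1)/C=C/c1ccc(O)c(OC)c1`, and compound 2, `CCC(C)NC(=C\C(=O)/C=C/c1ccc(O)c(OC)c1)/C=C/c1ccc(O)c(OC)c1`, share one core and differ only at the group on the amine nitrogen. In a functional assay on Caco-2 cells (Homo sapiens), read by fluorescence, tested at 1 uM (on this read-out higher numbers stand for a weaker effect at the one concentration tested and lower numbers for a stronger effect), compound 1 gives 97%, and compound 2 gives 91%, so the two numbers sit within the scatter of each other and compound 2 stands alongside compound 1 rather than apart from it. Within the data shown here, the only step measured so far, a number 6 percentage points lower from compound 1 to compound 2 (within the scatter), is small. Compound 3, `C=CCNC(=C\C(=O)/C=C/c1ccc(O)c(OC)c1)/C=C/c1ccc(O)c(OC)c1`, differs from compound 2 by allyl in place of sec-butyl on an amine nitrogen. Among the measured compounds shown here, since the one known change at this nitrogen, from compound 1 to compound 2, moved the read-out by little, a change between two other small chains at the same place is expected to do the same. For compound 3 the expected step is a number 3 percentage points higher from compound 2 to compound 3 (within the scatter), that is, none beyond the scatter. Compound 3 is therefore estimated at 94%, with a range from 84% to 100%.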

Compound 3, a percentage reported as activity, at one concentration (the size of the read-out at that concentration, not a potency): 89%
Estimate against measurement, compound 3: 5 percentage points above, within the range that was stated.
By their numbers in this assay, from the lowest: compounds 3, 2 and 1 (each within the scatter of the next).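

Replacing sec-butyl with allyl on the amine nitrogen gives a number 2 percentage points lower from compound 2 to compound 3 (within the scatter) in this assay and so adds a chain with a double bond to the saturated ones already seen at this position. The change read the other way, vinyl in place of ethyl on a saturated chain carbon bound to an amine nitrogen, gives a number 8 percentage points lower from compound 1 to compound 3 (within the scatter) and likewise stays inside the scatter, so neither this double bond nor the branching of sec-butyl separates these three compounds on this read-out. Nothing measured here offers an explanation for this result.

On these data alone, all three compounds carry small carbon chains on this nitrogen, so it remains open whether a benzyl group, a longer chain or a chain ending in a carboxylic acid would move the number beyond the scatter. The core also stays the same throughout, which leaves the effect of changes elsewhere on it unknown.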